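This account rests on a few compounds, and the source may have more. Where it says the series, first, only, none or still open, it means among the compounds named here.

In a functional assay on MDA-MB-231 cells (Homo sapiens) for inhibition, read by sulforhodamine B assay, with a stated time of 48 h (on this read-out lower numbers stand for stronger inhibition and higher numbers for weaker inhibition), compound 1 `COc1ccc(C(c2ccc(OCCO)cc2)c2cccc3ccccc23)c(OC)c1OC` gives > 20000 nM, which is a limit of the assay. Compound 2 `COc1ccc(C(c2ccccc2O)c2cccc3ccccc23)c(OC)c1OC` gives 17700 nM. Compound 3 `C=CCOC(c1ccc(OC)c(OC)c1OC)c1cccc2ccccc12` gives > 20000 nM, also only a limit, and so stands at the limit of > 20000 nM in this assay, at which 2 of the 3 values shown sit.

Compound 4 `COc1ccc(C(OCc2ccc(C)cc2)c2cccc3ccccc23)c(OC)c1OC` carries a changed ether group, allyloxy to (4-methylbenzyl)oxy: 4-methylphenyl in place of vinyl on a saturated chain carbon bound to an oxygen on a saturated carbon.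

The measured steps that end at the allyloxy group are an at least 1.1-fold higher number from compound 2 to compound 3 (0.05 log units; that floor lies within the scatter) and a step that the two limits leave unreadable from compound 1 to compound 3. Neither gives a size beyond the scatter, and neither alters the allyl group alone. No step beyond the scatter is therefore expected in this assay. The expected step is a number no higher from compound 3 to compound 4 (the limit leaves the size open). Compound 4 is estimated at 20000 nM, with an expected range from 9000 nM to 40000 nM.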

Compound 4, half-maximal inhibitory concentration: > 20000 nM
Compound 4: only a limit was reported (the forecaster's own chance of this, stated with the estimate: 70%); the middle value lies on the limit itself.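

In this assay compound 4 gives > 20000 nM, which is a limit of the assay. Within the data shown here, the steps to compound 4 from compound 1 and from compound 3 cannot be read, and the one readable step is an at least 1.1-fold higher number from compound 2 to compound 4 (0.05 log units; that floor lies within the scatter). Placing 4-methylphenyl in place of vinyl, and so adding an aromatic ring to the ether group, therefore brings no value inside the range of this assay: the limit of > 20000 nM in this assay, at which 3 of the 4 values shown sit.

Going by these compounds, whether an amine or a carboxylic acid in place of the 4-methylbenzyl group would give a value inside that range stays open. So does how compound 1, compound 3 and compound 4 rank among themselves.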